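This account rests on a few compounds, and the source may have more. Where it says the series, first, only, none or still open, it means among the compounds named here.

Compound 1 `C[C@H](NC(=O)[C@@H]1CCCN1C)c1ccc(NC(=O)N2CC(c3cccnc3)C2)cc1` anchors the series. In a physicochemical assay for solubility, read by LC-MS, in phosphate buffer, with a stated time of 24 h, at pH 6.8 (a higher number here means a more soluble compound, a lower number a less soluble compound), compound 1 gives > 1000000 nM, which is a limit of the assay rather than a number (the limit of > 1000000 nM in this assay, at which 1 of the 3 values shown sits). Compound 2 `CCC(=O)N[C@@H](C)c1ccc(NC(=O)N2CC(c3cccnc3)C2)cc1` differs from compound 1 by ethyl in place of 1-methylpyrrolidin-2-yl on a carbonyl carbon; in this assay compound 2 gives 700000 nM, the step being an at least 1.4-fold lower number from compound 1 to compound 2 (0.15 log units; that floor lies within the scatter). Compound 3 `C[C@H](NC(=O)[C@@H]1CCCN1C)c1ccc(NC(=O)N2CC(c3ccc(N)nc3)C2)cc1` gives 760000 nM in this assay, the step being an at least 1.3-fold lower number from compound 1 to compound 3 (0.11 log units; that floor lies within the scatter).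

Compound 4 `CCC(=O)N[C@@H](C)c1ccc(NC(=O)N2CC(c3ccc(N)nc3)C2)cc1` has not been measured in this assay. It differs from compound 3 by ethyl in place of 1-methylpyrrolidin-2-yl on a carbonyl carbon, the same change as that from compound 1 to compound 2, at the same place. The two cores differ by amino in place of hydrogen on an aromatic carbon.

Set beside an at least 1.4-fold lower number from compound 1 to compound 2 (0.15 log units; that floor lies within the scatter), the step expected from compound 3 to compound 4 is a 1.5-fold lower number from compound 3 to compound 4 (0.18 log units; within the scatter). That expectation rests on compound 2 at 700000 nM and on compound 3 at 760000 nM sitting within the scatter of each other. Compound 4 is estimated to give 500000 nM in this assay, between 250000 nM and 1000000 nM.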

Compound 4, solubility: 760000 nM
Estimate against measurement, compound 4: 1.5-fold (0.18 log units) below; the range from low to high includes it.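

In this assay, ethyl in place of 1-methylpyrrolidin-2-yl on a carbonyl carbon, carried to the core of compound 3, gives no change at the digits printed from compound 3 to compound 4 (within the scatter), while amino in place of hydrogen on an aromatic carbon gives a 1.1-fold higher number from compound 2 to compound 4 (0.04 log units; within the scatter). On the core of compound 1 the same change can be read only as a floor, because compound 1 stands at a limit of the assay and not at a number: the limit of > 1000000 nM in this assay, at which 1 of the 4 values shown sits. The change thus gives no step beyond the scatter on the core of compound 3, but whether its size matches on the two cores cannot be read, and two cores say nothing about any other core.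

Going by these compounds, whether a longer chain, an amine or a carboxylic acid in place of ethyl on the carbonyl carbon would give a step beyond the scatter in this assay remains open. So does the effect of methoxy or fluorine in place of amino on the aromatic carbon.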